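The compounds below may be only part of what the source reports. "The series", "measured", "known", "first", "only" and "open" are said of these compounds alone.

Working notes on the series. Compound 1 `CN(Cc1ccc(S(C)(=O)=O)cc1)C1CCN(CCCc2c[nH]c3ccc(-n4cnnc4)cc23)CC1`, compound 2 `C[C@@H](NCC1CCN(CCCc2c[nH]c3ccc(-n4cnnc4)cc23)CC1)c1ccccc1` and compound 3 `c1cncc(CNC2CCN(CCCc3c[nH]c4ccc(-n5cnnc5)cc34)CC2)c1` share one core and differ only in the group carried on a saturated ring carbon of the six-membered non-aromatic ring with 1 nitrogen. In an assay on CHO cells for displacement of a labelled ligand from 5-hydroxytryptamine receptor 1B (Homo sapiens) (a lower number here means a stronger inhibitor, a higher number a weaker inhibitor), compound 1 gives 140 nM, compound 2 gives 14 nM and compound 3 gives 140 nM. Among the compounds with values here, the one step recorded so far, a 10-fold higher number from compound 2 to compound 3 (1.00 log units; beyond the scatter), is the only one beyond the scatter. Compound 3 therefore stands level with compound 1 at the digits shown, the two together giving the highest numbers of the three, while compound 2 sits a full step below both.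

Compound 4 `CN(Cc1ccsc1)C1CCN(CCCc2c[nH]c3ccc(-n4cnnc4)cc23)CC1` is the next one, unmeasured in this assay. It differs from compound 3 as follows: methyl((thiophen-3-yl)methyl)amino in place of ((pyridin-3-yl)methyl)amino on a saturated ring carbon. Within the data shown here, no recorded step covers this exact change. The closest point of comparison is compound 1, which also carries a methyl on the amino nitrogen together with an arylmethyl group and sits at 140 nM, the same number as compound 3. On that basis a step of a 1.3-fold lower number from compound 3 to compound 4 (0.10 log units; within the scatter) is expected, that is, nothing beyond the scatter. Compound 4 is accordingly estimated at 110 nM in this assay, within a range of 35 nM to 350 nM.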

Compound 4, half-maximal inhibitory concentration: 35 nM
For compound 4 the middle estimate is 3.1-fold (0.50 log units) above the measured one; low and high end bracket the measured number.
By their numbers in this assay, from the lowest: compound 2; then compound 4; then compounds 1 and 3 (each within the scatter of the next).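

In this assay, the level numbers of compound 1 and compound 3 had suggested that the group on this saturated ring carbon might matter little once it lacked the ((1-phenylethyl)amino)methyl group, but methyl((thiophen-3-yl)methyl)amino in place of ((pyridin-3-yl)methyl)amino gives a 4.0-fold lower number from compound 3 to compound 4 (0.60 log units; beyond the scatter), so the position still responds to this type of group. With the methylated amine kept, thiophen-3-yl in place of 4-(methylsulfonyl)phenyl gives a 4.0-fold lower number from compound 1 to compound 4 (0.60 log units; beyond the scatter), which shows that the aromatic ring alone can move the number beyond the scatter. The ((1-phenylethyl)amino)methyl group remains unmatched, with a 2.5-fold higher number from compound 2 to compound 4 (0.40 log units; beyond the scatter), so the thiophene closes only part of the distance to that group.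

On these data alone, the change from compound 3 to compound 4 alters the aromatic ring and the methyl on the amino nitrogen together, so the share of each stays open, and how a thiophen-2-yl or furan-3-yl group on the same methylated amine would stand is also unknown. No measurement at hand accounts for any of these steps.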